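The source may report more compounds than this note shows. Statements on the series, on what has been measured and on what is new or still open speak of the compounds shown alone.

Of the compounds shown here, three have been measured: compound 1 `Cn1c(-c2ccc(NC(=O)CSc3nc4ccccc4o3)cc2)nc(-c2ccccc2)c1-c1ccccc1` with 56.2%, compound 2 `Cn1c(-c2ccc(NC(=O)CSc3nc4cc(Cl)ccc4o3)cc2)nc(-c2ccccc2)c1-c1ccccc1` with 42.5%, and compound 3 `Cc1nnc(SCC(=O)Nc2ccc(-c3nc(-c4ccccc4)c(-c4ccccc4)n3C)cc2)s1` with 83.3% in a functional assay on HT-29 cells (Homo sapiens) for cytotoxicity, read by MTT assay, with a stated time of 24 h, tested at 16 ug/mL; a higher number here means a stronger effect of the compound at the concentration tested, a lower number a weaker effect.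

Compound 2 stands lowest of the three; the nearest value is compound 1, reached by a number 13.7 percentage points lower from compound 1 to compound 2 (beyond the scatter), and the furthest is compound 3, reached by a number 40.8 percentage points higher from compound 2 to compound 3 (beyond the scatter). Compound 4 `CN(C)/C=C/N1CCN(CC(=O)Nc2ccc(-c3nc(-c4ccccc4)c(-c4ccccc4)n3C)cc2)CC1` has not been measured. It differs from compound 2 by 4-(2-(dimethylamino)ethenyl)piperazin-1-yl in place of (5-chloro-1,3-benzoxazol-2-yl)sulfanyl on a saturated chain carbon bound to a carbonyl carbon. The step of a number 40.8 percentage points higher from compound 2 to compound 3 (beyond the scatter) is the only one that removes the same group from the sulfur, and it was large; the step of a number 13.7 percentage points lower from compound 1 to compound 2 (beyond the scatter) places this chloro ring at the low end. Among the compounds with values here, no measured step replaces the sulfur link itself, so the expectation is uncertain. For compound 4 a rise of a number 17.5 percentage points higher from compound 2 to compound 4 (beyond the scatter) is expected, giving an estimated 60% within 35% to 85%.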

Compound 4, a percentage reported as activity, at one concentration (the size of the read-out at that concentration, not a potency): 28.2%
Estimate against measurement, compound 4: 31.8 percentage points above; measured number outside the range, below it.
By their numbers in this assay, from the lowest: compound 4; then compound 2; then compound 1; then compound 3.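

At this saturated chain carbon bound to a carbonyl carbon, the 4-(2-(dimethylamino)ethenyl)piperazin-1-yl group falls short of all three sulfanyl groups in this assay: a number 14.3 percentage points lower from compound 2 to compound 4 (beyond the scatter), a number 28 percentage points lower from compound 1 to compound 4 (beyond the scatter) and a number 55.1 percentage points lower from compound 3 to compound 4 (beyond the scatter). Losing the (5-chloro-1,3-benzoxazol-2-yl)sulfanyl group therefore does not by itself raise the number, and the earlier rise belongs to the (5-methyl-1,3,4-thiadiazol-2-yl)sulfanyl group. Nothing available explains this fall. Going by these compounds, whether the piperazine ring or its 2-(dimethylamino)ethenyl arm carries the fall stays open, as does what a morpholine or an unsubstituted piperazine would give at this carbon.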